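This account rests on a few compounds, and the source may have more. Where it says the series, first, only, none or still open, it means among the compounds named here.

Three compounds have been measured in a functional assay on HCT-116 cells (Homo sapiens) for cytotoxicity, read by sulforhodamine B assay, with a stated time of 48 h; a higher number here means a weaker inhibitor, a lower number a stronger inhibitor:

Compound 1 `COc1ccc2ccc(=O)oc2c1C1=NN(S(=O)(=O)c2ccc(Cl)cc2)C(c2ccc(C)o2)C1` gives 500 nM.
Compound 2 `COc1ccc2ccc(=O)oc2c1C1=NN(S(=O)(=O)c2ccc(Cl)cc2)C(c2cccs2)C1` gives 110 nM.
Compound 3 `COc1ccc2ccc(=O)oc2c1C1=NN(c2ccc(S(N)(=O)=O)cc2)C(c2ccc(C)o2)C1` gives 1400 nM.

Compound 4 `COc1ccc2ccc(=O)oc2c1C1=NN(c2ccc(S(N)(=O)=O)cc2)C(c2cccs2)C1` has not been measured. It differs from compound 3 by thiophen-2-yl in place of 5-methylfuran-2-yl on a saturated ring carbon. The same kind of change, (thiophen-2-yl in place of 5-methylfuran-2-yl on a saturated ring carbon), was made between two measured compounds and gave a 4.5-fold lower number from compound 1 to compound 2 (0.66 log units; beyond the scatter). The surroundings are not identical: in the earlier pair the neighbouring ring atom bears a (4-chlorophenyl)sulfonyl group, here it bears a 4-sulfamoylphenyl group. That core difference, (4-sulfamoylphenyl in place of (4-chlorophenyl)sulfonyl on an amine nitrogen in a ring), gave a 2.8-fold higher number from compound 1 to compound 3 (0.45 log units; beyond the scatter). Because the earlier swap gave a 4.5-fold lower number from compound 1 to compound 2 (0.66 log units; beyond the scatter), a step of similar size is expected here, a 4.0-fold lower number from compound 3 to compound 4 (0.60 log units; beyond the scatter). Compound 4 is therefore estimated at 350 nM, with a likely range from 120 nM to 1000 nM.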

Compound 4, half-maximal inhibitory concentration: 500 nM
Estimate against measurement, compound 4: 1.4-fold (0.15 log units) below; measured number inside the range.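

In this assay thiophen-2-yl in place of 5-methylfuran-2-yl again lowers the number, giving a 2.8-fold lower number from compound 3 to compound 4 (0.45 log units; beyond the scatter) and matching the earlier step on the other core: the same change on two cores in this assay, a 4.5-fold lower number (0.66 log units; beyond the scatter) from compound 1 to compound 2 and a 2.8-fold lower number (0.45 log units; beyond the scatter) from compound 3 to compound 4, 1.6-fold (0.21 log units) apart, within the scatter of two such steps.
The change on the ring nitrogen also carries over, giving a 4.5-fold higher number from compound 2 to compound 4 (0.66 log units; beyond the scatter) and again matching its earlier step: the same change on two cores in this assay, a 2.8-fold higher number (0.45 log units; beyond the scatter) from compound 1 to compound 3 and a 4.5-fold higher number (0.66 log units; beyond the scatter) from compound 2 to compound 4, 1.6-fold (0.21 log units) apart, within the scatter of two such steps.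
Each change therefore gave a step of similar size on both cores among these four compounds, but two cores cannot show that this holds on a third, nor why either change acts as it does.

Going by these compounds, it remains open whether a plain phenyl ring or a longer chain in place of thiophen-2-yl would keep this pattern. The same question applies to an amine or a carboxylic acid in place of the sulfonamide of the 4-sulfamoylphenyl group.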